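The source may report more compounds than this note shows. Statements on the series, on what has been measured and on what is new or still open speak of the compounds shown alone.

Compound 3 `C/C=C1/[C@H](O[C@@H]2O[C@H](CO)[C@@H](O)[C@H](O)[C@H]2O)OC=C(C(=O)OC)[C@H]1CC(=O)OCCC` was tested in a functional assay on SK-BR-3 cells (Homo sapiens) for antiproliferative activity, read by MTT assay, with a stated time of 72 h; a lower number here means a stronger inhibitor, a higher number a weaker inhibitor. In this assay compound 3 gives > 15000 nM, which is a limit of the assay and not a number. Its two relatives on the shared core stand in the same way. Compound 2 `C#CCOC(=O)C[C@@H]1C(C(=O)OC)=CO[C@@H](O[C@@H]2O[C@H](CO)[C@@H](O)[C@H](O)[C@H]2O)/C1=C/C` gives > 15000 nM, again a limit. Compound 1 `C/C=C1/[C@H](O[C@@H]2O[C@H](COC(C)=O)[C@@H](OC(C)=O)[C@H](OC(C)=O)[C@H]2OC(C)=O)OC=C(C(=O)OC)[C@H]1CC(=O)SCCc1ccccc1` gives > 15000 nM, also a limit. All values shown sit at the limit (the limit of > 15000 nM in this assay, at which 3 of the 3 values shown sit). Going by the values given here, the one measured step between neighbours, a step that the two limits leave unreadable from compound 2 to compound 3, cannot be read in size; both of its ends are limits.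

Compound 4 `C/C=C1/[C@H](O[C@@H]2O[C@H](CO)[C@@H](O)[C@H](O)[C@H]2O)OC=C(C(=O)OC)[C@H]1CC(=O)OCCCC` differs from compound 3 by methyl in place of hydrogen on a saturated chain carbon, three bonds along the chain from an oxygen next to a carbonyl group. Among the compounds with values here, no measured step gives a readable size for a change of this kind, and no value shown rises above the limit. Nothing therefore points to a change in either direction beyond the scatter, and the step that the limit leaves unreadable from compound 3 to compound 4 is expected to stay within it. Compound 4 is estimated at 20000 nM, between 8000 nM and 60000 nM, and is expected most likely to be reported once more as a limit.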

Compound 4, half-maximal inhibitory concentration: > 15000 nM
Compound 4 ended at the assay's limit; the forecaster's own chance of this, stated with the estimate: 85%; the middle value does not contradict the limit.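

The steps to compound 4 from compound 2 and from compound 3 cannot be read in size, as both ends of each are limits and not numbers. The compounds shown leave open how strongly each acts and whether any change to the shared core gives a readable value.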